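Urea aryl variation on the shared core: toward compound 4

The source may report more compounds than this note shows. Statements on the series, on what has been measured and on what is new or still open speak of the compounds shown alone.

Compound 3 `COc1cc(Cl)cc(-c2nn(-c3cccc(NC(=O)Nc4ccc(Cl)c(Cl)c4)c3)cc2-c2ccncc2)c1` gives 62% in a functional assay on HT-29 cells (Homo sapiens) for inhibition, read by sulforhodamine B assay, with a stated time of 48 h, tested at 1 uM (a higher number here means a weaker effect of the compound at the concentration tested, a lower number a stronger effect), the highest of the three numbers. Compound 1 `COc1cc(Cl)cc(-c2nn(-c3cccc(NC(=O)Nc4ccc(Cl)c(C(F)(F)F)c4)c3)cc2-c2ccncc2)c1` gives 55% in this assay, within the scatter of compound 3; compound 2 `COc1cc(Cl)cc(-c2nn(-c3cccc(NC(=O)Nc4cc(C(F)(F)F)cc(C(F)(F)F)c4)c3)cc2-c2ccncc2)c1` gives 23%, a gap beyond the scatter. Compound 4 `COc1cc(Cl)cc(-c2nn(-c3cccc(NC(=O)Nc4cccc(C(F)(F)F)c4)c3)cc2-c2ccncc2)c1` carries 3-(trifluoromethyl)phenyl in place of 3,4-dichlorophenyl on an amide-type nitrogen. Among the measured compounds shown here, the one measured step bearing on it is a number 7 percentage points higher from compound 1 to compound 3 (within the scatter), so exchanging chloro for trifluoromethyl on that ring has not moved the read-out beyond the scatter. For the measured compounds named here, no measured pair isolates the 3-(trifluoromethyl)phenyl urea itself. For compound 4 a step of no change at the digits printed from compound 3 to compound 4 (within the scatter) is expected, nothing beyond the scatter. Compound 4 is therefore estimated at 62% in this assay, with a range of 42% to 82%.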

Compound 4, a percentage reported as activity, at one concentration (the size of the read-out at that concentration, not a potency): 65%
The estimate for compound 4 lay 3 percentage points below the measured number; the range from low to high includes it.
By their numbers in this assay, from the lowest: compound 2; then compounds 1, 3 and 4 (each within the scatter of the next).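

On the amide-type nitrogen, 3-(trifluoromethyl)phenyl and 3,4-dichlorophenyl are not separated in this assay, with a number 3 percentage points higher from compound 3 to compound 4 (within the scatter) for this exchange. Hydrogen in place of chloro gives a number 10 percentage points higher from compound 1 to compound 4 (within the scatter) while hydrogen in place of trifluoromethyl gives a number 42 percentage points higher from compound 2 to compound 4 (beyond the scatter) and so, among these four ureas, only the second trifluoromethyl of compound 2 sets a compound apart. No measurement available here bears on a cause for this.

Going by these compounds, whether a different second group on this ring, such as a nitrile or a carboxylic acid, would match compound 2 stays open.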